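The compounds below may be only part of what the source reports. "The series", "measured", "known", "first", "only" and "open" are said of these compounds alone.

Measured compounds:
compound 1, `CC(C)=CCC/C(C)=C/CC/C(C)=C/CSC[C@H](NC(=O)CCCCCN1CCCC1)C(=O)NC1CCCCC1`, 12700 nM
compound 2, `CC(C)=CCC/C(C)=C/CC/C(C)=C/CSC[C@H](NC(=O)CCCCCN1CCN(C)CC1)C(=O)N1CCCC1`, 3200 nM
compound 3, `CC(C)=CCC/C(C)=C/CC/C(C)=C/CSC[C@H](NC(=O)CCCCCN1CCCC1)C(=O)N1CCCCC1`, 8700 nM

All three numbers come from a functional assay on BXPC-3 cells (Homo sapiens) for cytotoxicity, read by fluorescence, with a stated time of 48 h; a lower number here means that less compound is needed, a higher number that more compound is needed for the effect. Compound 2 gives the lowest number of the three. Compound 3 gives 8700 nM, and compound 1 gives 12700 nM; the gaps from compound 2 to each of them lie beyond the scatter. Compound 1 and compound 3 share every part except the amide end, and the step of a 1.5-fold lower number from compound 1 to compound 3 (0.16 log units; within the scatter) stays within the scatter.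

Compound 4, `CC(C)=CCC/C(C)=C/CC/C(C)=C/CSC[C@H](NC(=O)CCCCCN1CCN(C)CC1)C(=O)NC1CCCC1`, is not yet measured. Its change from compound 2 is cyclopentylamino in place of pyrrolidin-1-yl on a carbonyl carbon. Among the measured compounds shown here, the only measured step that bears on it is the one from compound 1 to compound 3, which exchanges a cyclic secondary amide for a ring amine of one more ring carbon and stays within the scatter; the step to compound 4 runs the same exchange the other way. No step beyond the scatter is therefore expected in this assay, at most a slight rise in the number.

For compound 4 the estimate is 4500 nM, with a range from 2000 nM to 10000 nM. This estimate means an expected step of a 1.4-fold higher number from compound 2 to compound 4 (0.15 log units; within the scatter).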

Compound 4, half-maximal effective concentration: > 20000 nM
Compound 4 was reported as a limit (the forecaster's own chance of this, stated with the estimate: 5%); middle value at least 4.4-fold (0.64 log units) away from the limit.
By their numbers in this assay, from the lowest: compound 2; then compounds 3 and 1 (each within the scatter of the next). At a limit, above all of these: compound 4.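

In this assay, the reading for compound 4 is a limit: the limit of > 20000 nM in this assay, at which 1 of the 4 values shown sits.

Even so, cyclopentylamino in place of pyrrolidin-1-yl on a carbonyl carbon gives an at least 6.2-fold higher number from compound 2 to compound 4 (0.79 log units; beyond the scatter), so this position is not indifferent to the change when the rest of compound 2 is kept. The earlier exchange of a related kind, with a 1.5-fold lower number from compound 1 to compound 3 (0.16 log units; within the scatter), did not show this, and that pair also carries a different group at the far end of the chain, so the outcome of such an exchange is not the same in the two pairs.

Open, from the compounds shown here alone, is whether the difference follows the amide hydrogen, which cyclopentylamino has and pyrrolidin-1-yl lacks, or the ring itself; a methyl group on the amide nitrogen of compound 4 would separate the two. Also open, going by these compounds, is the true size of the step from the limit.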